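A few compounds are considered here, and "the series" means these few. Any claim that something is new, unique, unknown or untested is made for them only; others in the source may bear on it.

Working notes on the series. The shared core of compound 1 `COc1cc(-c2cc(/C=C/C(=O)c3ccc(N)cc3)[nH]n2)cc(OC)c1OC` carries a 4-aminophenyl on the carbonyl carbon; in a functional assay on KM12 cells (Homo sapiens) for cytotoxicity, read by sulforhodamine B assay, with a stated time of 48 h, tested at 10 uM (on this read-out lower numbers stand for a stronger effect and higher numbers for a weaker effect at the one concentration tested), compound 1 gives -67%. Compound 2 `COc1ccc(C(=O)/C=C/c2cc(-c3cc(OC)c(OC)c(OC)c3)n[nH]2)cc1OC` gives -87%, the lowest number of the three, and compound 3 `COc1cc(-c2cc(/C=C/C(=O)c3ccc(F)c(F)c3)[nH]n2)cc(OC)c1OC` gives 3%. The steps measured so far are a number 20 percentage points lower from compound 1 to compound 2 (beyond the scatter), a number 70 percentage points higher from compound 1 to compound 3 (beyond the scatter) and a number 90 percentage points higher from compound 2 to compound 3 (beyond the scatter); all of them exchange the whole ring on the carbonyl carbon. The next step goes from compound 2 to compound 4 `COc1cc(C(=O)/C=C/c2cc(-c3cc(OC)c(OC)c(OC)c3)n[nH]2)cc(OC)c1OC`: methoxy in place of hydrogen on an aromatic carbon. For the measured compounds named here, no measured step adds a single methoxy to a ring already bearing two, so the bearing of the earlier steps is indirect. A step no larger than modest is expected, a number 7 percentage points higher from compound 2 to compound 4 (within the scatter). For compound 4 the estimate is -80%, within -100% to -50%.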

Compound 4, a percentage reported as activity, at one concentration (the size of the read-out at that concentration, not a potency): -90%
Compound 4: middle estimate off by 10 percentage points, on the high side, within the range that was stated.
By their numbers in this assay, from the lowest: compounds 4 and 2 (each within the scatter of the next); then compound 1; then compound 3.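

The added methoxy, ortho to a methoxy group and meta to a large group, gives a number 3 percentage points lower from compound 2 to compound 4 (within the scatter) in this assay and so leaves the read-out inside the scatter. Unlike the earlier exchanges of the whole ring, this step changes one position on the ring, and the strong effect of compound 2 persists in compound 4. Nothing available here explains this result. Still open, as far as these compounds go, is whether a hydroxy, an ethoxy or a chlorine at this position would keep that effect, and whether an amine there would do so.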